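Moving the chlorine on the benzyl arm of compound 2

A few compounds are considered here, and "the series" means these few. Any claim that something is new, unique, unknown or untested is made for them only; others in the source may bear on it.

Measured compounds:
compound 1, `CC1=C(C(=O)Nc2ccc([N+](=O)[O-])cc2)C(c2ccc(Br)cc2)N=C(SCc2cccc(Cl)c2)N1`, gives 2.6%
compound 2, `CC1=C(C(=O)Nc2ccc([N+](=O)[O-])cc2)C(c2cccc([N+](=O)[O-])c2)N=C(SCc2ccccc2Cl)N1`, gives 7.2%

In a functional assay on the whole organism (artery, strain albino) with Rattus norvegicus as the target, with a stated time of 900 min, at a dose of 10 mg/kg by the oral route (a higher number here means more inhibition at the dose given (going by the name of the read-out), a lower number less inhibition), compound 1 gives 2.6%, and compound 2 gives 7.2%. Compound 2 has the higher of the two numbers, yet the gap to compound 1 lies within the scatter, so the two cannot be told apart, and both sit near the bottom of the scale. Within the data shown here, no single-change step between measured compounds is available, as compounds 1 and 2 differ in two places.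

Compound 3, `CC1=C(C(=O)Nc2ccc([N+](=O)[O-])cc2)C(c2cccc([N+](=O)[O-])c2)N=C(SCc2cccc(Cl)c2)N1`, differs from compound 2 in one place: 3-chlorophenyl in place of 2-chlorophenyl on a saturated chain carbon bound to a sulfur, that is, a 2-chlorobenzyl group becomes a 3-chlorobenzyl group. Among the measured compounds shown here, no measured step of this kind exists here. The step of a number 2.2 percentage points lower from compound 2 to compound 3 (within the scatter) is expected to be small, within the scatter, in either direction. Compound 3 is therefore estimated to give 5%, with a range from 0% to 15%.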

Compound 3, a percentage reported as inhibition, in the whole organism at one dose (the size of the read-out at that dose, not a potency): 10.8%
Compound 3: the middle estimate sits 5.8 percentage points below what was measured, and the stated range covers the measured number.
By their numbers in this assay, from the lowest: compounds 1, 2 and 3 (each within the scatter of the next).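

In this assay, moving the chlorine from a 2-chlorobenzyl group to a 3-chlorobenzyl group gives a number 3.6 percentage points higher from compound 2 to compound 3 (within the scatter). Among these compounds, this is the first direct test at this position, and it shows that swapping these two chlorobenzyl groups leaves no readable difference. The other single change, 3-nitrophenyl in place of 4-bromophenyl on a saturated ring carbon, gives a number 8.2 percentage points higher from compound 1 to compound 3 (within the scatter), so that place shows no readable difference either, and nothing available accounts for these numbers.

From the compounds shown here alone, what stays open is whether any change on these two arms can move the number clear of the scatter at all. An amine or a carboxylic acid on the benzyl ring, or a longer chain between the sulfur and the ring, might answer that, since all three compounds share a chlorobenzyl arm.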